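This account rests on a few compounds, and the source may have more. Where it says the series, first, only, none or still open, it means among the compounds named here.

Compound 2 `CCc1nc(Cl)c2n1CCN([C@@H](C(=O)NC)c1ccccc1)[C@H]2CCc1ccc(C(F)(F)F)cc1F` and compound 1 `CCc1nc(Cl)c2n1CCN([C@@H](C(=O)NC)c1ccccc1)[C@H]2CCc1ccc(C(F)(F)F)c(Cl)c1` share the same core and differ only in the aromatic ring at the end of the two-carbon chain. In a functional assay on CHO cells for antagonist activity at Orexin receptor type 2 (Homo sapiens), read by FLIPR and calcium flux (on this read-out lower numbers stand for stronger inhibition and higher numbers for weaker inhibition), compound 1 gives 18 nM, and compound 2 gives 12 nM. The change from compound 1 to compound 2 reads a 1.5-fold lower number from compound 1 to compound 2 (0.18 log units; within the scatter), so the two numbers lie within the usual scatter of each other and neither compound can be called the more potent on these figures alone; compound 2 simply holds the lower of the two numbers shown.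

Compound 3 `CCc1nc(Cl)c2n1CCN([C@@H](C(=O)NC)c1ccccc1)[C@H]2CCc1ccc(C(F)(F)F)c(F)c1F` takes one further step on that same ring: fluoro in place of hydrogen on an aromatic carbon. Going by the values given here, the only measured step that bears on this position of the molecule is the one from compound 1 to compound 2, and it stayed within the scatter even though it moved a halogen from one ring position to another. Adding a second fluoro group is a smaller alteration than that swap, so in this assay no step beyond the scatter is expected for compound 3, with no change at the digits printed from compound 2 to compound 3 (within the scatter). Compound 3 is therefore estimated at 12 nM, with a range from 5 nM to 30 nM.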

Compound 3, half-maximal inhibitory concentration: 14 nM
Compound 3: the middle estimate sits 1.2-fold (0.07 log units) below what was measured, within the range that was stated.
By their numbers in this assay, from the lowest: compounds 2, 3 and 1 (each within the scatter of the next).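

In this assay, placing a fluoro on the aromatic carbon ortho to a fluoro group and ortho to a trifluoromethyl group gives a 1.2-fold higher number from compound 2 to compound 3 (0.07 log units; within the scatter) and so makes no readable difference at this position. Going by these compounds alone, this is the first direct look at that carbon, as the earlier pair showed only what happens when the ring's halogen pattern is exchanged, not when one atom is added to an otherwise unchanged ring. The larger exchange, 2,3-difluoro-4-(trifluoromethyl)phenyl in place of 3-chloro-4-(trifluoromethyl)phenyl, gives a 1.3-fold lower number from compound 1 to compound 3 (0.11 log units; within the scatter) and is also within the scatter, so all three ring patterns shown cannot be told apart here, and no available measurement offers an explanation for this.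

A single fluoro is the only group shown on this carbon, so it remains open whether something of another kind there, such as a methoxy group, a nitrile or an amine, would also leave the number within the scatter. All three compounds also keep the trifluoromethyl group, leaving open what would follow if it gave way to a hydrogen or a methyl group.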